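Carbonyl in place of benzyl on a piperidine-bearing antagonist

The compounds below may be only part of what the source reports. "The series", "measured", "known", "first", "only" and "open" are said of these compounds alone.

Compound 3 `CNC(=O)c1cnc(N2CCN(C3CCN(Cc4ccc(Cl)cc4F)CC3)[C@@H](C)C2)c(Cl)c1` gives the lowest number of the three measured compounds in a functional assay for antagonist activity at C-X-C chemokine receptor type 3 (Homo sapiens) (a higher number here means a weaker inhibitor, a lower number a stronger inhibitor), at 18 nM. Compound 2 `CNC(=O)c1cnc(N2CCN(C3CCN(C(F)(F)F)CC3)[C@@H](C)C2)c(Cl)c1` gives 63 nM, and compound 1 `CNC(=O)c1cnc(N2CCN(C3CCN(Cc4ccco4)CC3)[C@@H](C)C2)c(Cl)c1` gives 8100 nM. Compound 4 `CNC(=O)c1cnc(N2CCN(C3CCN(C(=O)c4ccc(Cl)cc4)CC3)[C@@H](C)C2)c(Cl)c1` differs from compound 3 by (4-chlorophenyl)carbonyl in place of 4-chloro-2-fluorobenzyl on an amine nitrogen in a ring. Going by the values given here, no measured step changes the carbonyl itself; the nearest guides are the steps of a 3.5-fold lower number from compound 2 to compound 3 (0.54 log units; beyond the scatter) and a 450-fold lower number from compound 1 to compound 3 (2.65 log units; beyond the scatter), which show that the group on this nitrogen can move the number by a modest or a large amount. With the chlorophenyl retained, compound 4 is expected to sit a modest step weaker, a 5.6-fold higher number from compound 3 to compound 4 (0.74 log units; beyond the scatter). Compound 4 is therefore estimated at 100 nM, within a range from 20 nM to 600 nM.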

Compound 4, half-maximal inhibitory concentration: 210 nM
Compound 4: the middle estimate sits 2.1-fold (0.32 log units) below what was measured; low and high end bracket the measured number.
By their numbers in this assay, from the lowest: compound 3; then compound 2; then compound 4; then compound 1.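

In this assay, replacing 4-chloro-2-fluorobenzyl with (4-chlorophenyl)carbonyl on this nitrogen costs a large step (a 12-fold higher number from compound 3 to compound 4 (1.07 log units; beyond the scatter)), so this position does not tolerate the carbonyl-linked group as well as the benzyl group. The same group also falls short of trifluoromethyl (a 3.3-fold higher number from compound 2 to compound 4 (0.52 log units; beyond the scatter)), yet it far outperforms (furan-2-yl)methyl (a 39-fold lower number from compound 1 to compound 4 (1.59 log units; beyond the scatter)), placing it third of the four compounds. Nothing available explains these differences.

The step from compound 3 also removes the fluorine, leaving the carbonyl's own share unresolved; a 4-chlorobenzyl group would separate the two changes. On these data alone, how a sulfonyl or urea linker to the chlorophenyl would fare remains open.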